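Swapping a Ring Amine on a Receptor Antagonist Core

The compounds below may be only part of what the source reports. "The series", "measured", "known", "first", "only" and "open" are said of these compounds alone.

Compound 1 `CCN(c1nc(C)cc(N2CCCCC2)n1)c1ccc(C(C)C)cc1Br` and compound 2 `CCN(CC)c1nc(C)nc(N(CC)c2ccc(C(C)=O)cc2Br)n1` were both examined in an assay on isolated protein for binding affinity to corticotropin-releasing factor receptor 1 (Homo sapiens); a higher number here means a weaker inhibitor, a lower number a stronger inhibitor. In this assay compound 1 gives 29 nM, and compound 2 gives 17 nM. Compound 1 stands at the higher of these two numbers, but the gap between them is within the usual scatter of repeated measurements, so neither compound can be called the tighter binder on this evidence.

Compound 3 `CCCN(c1cc(C)nc(N(CC)c2ccc(C(C)C)cc2Br)n1)C1CC1` has not yet been measured. It keeps the core of compound 1 and its ethyl-linked aryl group, and differs in one substituent only: cyclopropyl(propyl)amino in place of piperidin-1-yl on an aromatic carbon. Going by the values given here, both the group that leaves and the group that enters are amines joined to the shared core through their nitrogen, and no measured pair here shows what such a swap does. The step from compound 1 to compound 3 in this assay is expected to be a 1.0-fold higher number from compound 1 to compound 3 (0.01 log units; within the scatter), small enough to fall within the scatter. Compound 3 is therefore estimated at 30 nM, with a plausible range from 10 nM to 90 nM.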

Compound 3, inhibition constant: 5 nM
For compound 3 the middle estimate is 6.0-fold (0.78 log units) above the measured one; measured number below the stated range.
By their numbers in this assay, from the lowest: compound 3; then compounds 2 and 1 (each within the scatter of the next).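

Placing cyclopropyl(propyl)amino in place of piperidin-1-yl on this aromatic carbon gives, in this assay, a 5.8-fold lower number from compound 1 to compound 3 (0.76 log units; beyond the scatter). This shows that the position is not indifferent to which amine it carries, even when both groups are joined to the shared core through their nitrogen. The two groups have the same counts of hydrogen-bond donors and acceptors and no net charge, so those counts do not separate them, and no measurement here explains the lower number.

A single pair cannot show whether the cyclopropyl ring, the propyl chain or the opening of the piperidine ring accounts for the step, and a dipropylamino group or a cyclopropyl(butyl)amino group, with its longer chain, would help to separate these parts of the change. From the compounds shown here alone, it also remains open whether the same swap would give a similar step on the core of compound 2, which differs from compound 1 in more than one place.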